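The source may hold more compounds than are shown below. What is called first, only, known or untested is meant among the compounds shown, and "the series" means these compounds.

Measured in an ADME assay on CCRF-CEM cells (Homo sapiens) for cytotoxicity, read by MTT assay, with a stated time of 5 days; on this read-out higher numbers stand for lower toxicity in this test and lower numbers for higher toxicity in this test:
- Compound 1 `COc1cc(Cc2cnc(/N=C3\C(=O)N(CN4CCCCC4C)c4ccc(Cl)cc43)nc2N)cc(OC)c1OC`: > 83.8 ug/mL (a limit)
- Compound 2 `COc1cc(Cc2cnc(/N=C3\C(=O)N(CN(Cc4ccccc4)Cc4ccccc4)c4ccc(Cl)cc43)nc2N)cc(OC)c1OC`: 37.1 ug/mL

Compound 1 stands at > 83.8 ug/mL, which is a limit of the assay and not a number. Compound 2 gives a measured number, 37.1 ug/mL. Compound 3 `CCN(CC)CN1C(=O)/C(=N\c2ncc(Cc3cc(OC)c(OC)c(OC)c3)c(N)n2)c2cc(Cl)ccc21` keeps the core of compound 1 and differs in one place: diethylamino in place of 2-methylpiperidin-1-yl on a saturated chain carbon bound to an amide-type nitrogen in a ring. Among the compounds with values here, no measured pair shows this change alone, so in this assay only a modest step towards lower numbers is expected, an at least 1.2-fold lower number from compound 1 to compound 3 (0.11 log units; that floor lies within the scatter). A result at the limit would not be surprising. For compound 3 the estimated value is 65 ug/mL, with an expected range from 25 ug/mL to 120 ug/mL.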

Compound 3, half-maximal cytotoxic concentration: 98.4 ug/mL
Compound 3: middle estimate off by 1.5-fold (0.18 log units), on the low side; the measured number falls inside the stated range.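

No step can be read from compound 1 to compound 3 in this assay, as the value of compound 1 is a limit: the limit of > 83.8 ug/mL in this assay, at which 1 of the 3 values shown sits.

The compounds shown leave open how far, if at all, diethylamino in place of 2-methylpiperidin-1-yl shifts the read-out.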